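Series notes: the amide benzyl of compound 1 removed

The source may hold more compounds than are shown below. What is called first, only, known or untested is meant among the compounds shown, and "the series" means these compounds.

Compound 1 `Cc1ccc2c(c1)C1(C(=O)N2Cc2ccccc2)C(C#N)=C(N)Oc2cc3oc(-c4ccccc4)cc(=O)c3c(O)c21`: in a functional assay on NCI-H1299 cells (Homo sapiens) for antiproliferative activity, read by MTT assay, with a stated time of 48 h (on this read-out higher numbers stand for weaker inhibition and lower numbers for stronger inhibition), compound 1 gives > 50000 nM, which is a limit of the assay.
Compound 2 `N#CC1=C(N)Oc2cc3oc(-c4ccccc4)cc(=O)c3c(O)c2C12C(=O)N(Cc1ccccc1)c1ccc(F)cc12`: compound 2 gives > 50000 nM, again a limit.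
Compound 3 `N#CC1=C(N)Oc2cc3oc(-c4ccccc4)cc(=O)c3c(O)c2C12C(=O)N(Cc1ccccc1)c1ccc(Br)cc12`: compound 3 gives > 50000 nM, again a limit.

Compound 1 therefore stands at the limit, as do the other two (the limit of > 50000 nM in this assay, at which 3 of the 3 values shown sit). Because a step that the two limits leave unreadable from compound 1 to compound 2, a step that the two limits leave unreadable from compound 1 to compound 3 and a step that the two limits leave unreadable from compound 2 to compound 3 each run from a limit to a limit, none of them can be read. Compound 4 `Cc1ccc2c(c1)C1(C(=O)N2)C(C#N)=C(N)Oc2cc3oc(-c4ccccc4)cc(=O)c3c(O)c21` differs from compound 1 by hydrogen in place of benzyl on an amide-type nitrogen in a ring. The measured steps all concern the aromatic substituent, not the amide-type nitrogen, so none bears on this change and no direction follows from them. For compound 4 the estimate is 50000 nM, with a range from 10000 nM to 200000 nM, most probably reported once more only as a limit. The implied step a number no higher from compound 1 to compound 4 (the limit leaves the size open) is expected to stay within scatter.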

Compound 4, half-maximal inhibitory concentration: > 50000 nM
Compound 4 was reported as a limit; the forecaster's own chance of this, stated with the estimate: 75%; the middle value lies on the limit itself.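

No new step can be read, since compound 4 and compound 1 both sit at a limit, as do compound 2 and compound 3: the limit of > 50000 nM in this assay, at which 4 of the 4 values shown sit.

The compounds shown leave open whether any change to the shared core gives a value within the assay's range.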